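A few compounds are considered here, and "the series" means these few. Any claim that something is new, unique, unknown or untested is made for them only; others in the source may bear on it.

Compound 3, with the structure `CCCC(=O)NC(=S)N1CCc2c(OCCCCCOc3ccc(Cl)cc3)cccc21`, sits at the edge of what the test can report. In an ADME assay on Huh-7 cells (Homo sapiens) for cytotoxicity (on this read-out lower numbers stand for higher toxicity in this test and higher numbers for lower toxicity in this test), compound 3 gives > 50000 nM, which is a limit of the assay and not a number. Compound 1, `NC(=S)N1CCc2c(OCCCCCOc3ccc(Cl)cc3)cccc21`, also reaches that limit: in this assay compound 1 gives > 50000 nM. Compound 2, `O=C(NC(=S)N1CCc2c(OCCCCCOc3ccc(Cl)cc3)cccc21)c1ccc(Br)cc1`, is the only one of the three with a number: in this assay compound 2 gives 29100 nM. The step from the unsubstituted amide-type nitrogen to the bromophenyl-carbonyl reads an at least 1.7-fold lower number from compound 1 to compound 2 (0.23 log units; that floor lies within the scatter), the step to the propylcarbonyl reads a step that the two limits leave unreadable from compound 1 to compound 3, and the step between the two carbonyl groups reads an at least 1.7-fold higher number from compound 2 to compound 3 (0.23 log units; that floor lies within the scatter). Two of the three values therefore stand at the limit of > 50000 nM in this assay, at which 2 of the 3 values shown sit.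

Compound 4, `O=C(NC(=S)N1CCc2c(OCCCCCOc3ccc(Cl)cc3)cccc21)C1CCCC1`, differs from compound 3 in one place: cyclopentyl in place of propyl on a carbonyl carbon. Among the compounds with values here, the only measured step that touches the same position is the one from compound 2 to compound 3, where a propyl replaced a 4-bromophenyl and the number moved up to the limit. Within the data shown here, no measured step shows a cyclopentyl. The expectation is therefore that compound 4 stays near the limit, with a change of a step that the limit leaves unreadable from compound 3 to compound 4, not beyond the scatter. For compound 4 in this assay the estimate is 60000 nM, within 30000 nM to 150000 nM.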

Compound 4, half-maximal cytotoxic concentration: > 50000 nM
Compound 4: a limit, no number (the forecaster's own chance of this, stated with the estimate: 70%); the middle value lies beyond the limit too.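

The cyclopentyl group brings a non-aromatic ring and more carbon to this carbonyl carbon than propyl does, yet in this assay compound 4 still gives only a limit, not a number. Within the data shown here, a saturated ring at this position therefore behaves like the open propyl chain, at least as far as this test can report, and compound 2, with its 4-bromophenyl, remains the only one of the four compounds with a readable value. Exchanging that 4-bromophenyl for cyclopentyl gives an at least 1.7-fold higher number from compound 2 to compound 4 (0.23 log units; that floor lies within the scatter), so this comparison does not establish a real difference, and the steps to compound 4 from compound 3 and from compound 1 cannot be read, because both ends of each step sit at a limit: the limit of > 50000 nM in this assay, at which 3 of the 4 values shown sit.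

The compounds shown leave open whether the value of compound 2 goes with the aromatic ring or with the bromine, a question that an unsubstituted phenyl on the same carbonyl carbon would address. They also leave open whether a group carrying an amine or a carboxylic acid at this position would bring the value down to a readable number.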